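A few compounds are considered here, and "the series" means these few. Any claim that something is new, unique, unknown or untested is made for them only; others in the source may bear on it.

Values in an ADME assay (liver) for metabolic stability, with Liver microsome (Homo sapiens) as the target, using microsomes and NADPH, with a stated time of 30 min, tested at 1 uM; a higher number here means faster removal of the compound, a lower number slower removal:
compound 1 `Nc1ccc(S(=O)(=O)N2CCN(c3ncc(C(O)(C(F)(F)F)C(F)(F)F)cc3-c3ccoc3)CC2)cn1`: < 14 mL.min-1.g-1
compound 2 `Nc1ccc(S(=O)(=O)N2CCN(c3ncc(C(O)(C(F)(F)F)C(F)(F)F)cc3-c3cccc(F)c3)CC2)cn1`: 25 mL.min-1.g-1
compound 3 `COc1cncc(-c2cc(C(O)(C(F)(F)F)C(F)(F)F)cnc2N2CCN(S(=O)(=O)c3ccc(N)nc3)CC2)c1`: 44 mL.min-1.g-1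

The entry for compound 1 is a limit of the assay, not a number. Compound 3 stands level with compound 2 within the scatter, with a 1.8-fold higher number from compound 2 to compound 3 (0.25 log units; within the scatter). Compound 4 `Nc1ccc(S(=O)(=O)N2CCN(c3ncc(C(O)(C(F)(F)F)C(F)(F)F)cc3-c3ccc4sccc4c3)CC2)cn1` changes the same aromatic carbon: 1-benzothiophen-5-yl in place of 5-methoxypyridin-3-yl on an aromatic carbon. Two further measured steps at that carbon bear on it: an at least 1.7-fold higher number from compound 1 to compound 2 (0.25 log units; that floor lies within the scatter) and an at least 3.1-fold higher number from compound 1 to compound 3 (0.49 log units; beyond the scatter). Both point upward, but neither brings in a pair of fused rings. A small upward step, not clearly beyond the scatter, is therefore expected in this assay. The estimated step is a 1.5-fold higher number from compound 3 to compound 4 (0.17 log units; within the scatter). For compound 4 the estimated value is 65 mL.min-1.g-1, with an expected range of 25 mL.min-1.g-1 to 150 mL.min-1.g-1.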

Compound 4, intrinsic clearance in microsomes: 48 mL.min-1.g-1
Beside the measured number, compound 4's estimate is 1.4-fold (0.13 log units) above it; measured number inside the range.
By their numbers in this assay, from the lowest: compounds 2, 3 and 4 (each within the scatter of the next). At a limit, below all of these: compound 1.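

In this assay, a pair of fused rings at this aromatic carbon does not separate from the single six-membered rings: 1-benzothiophen-5-yl gives a 1.1-fold higher number from compound 3 to compound 4 (0.04 log units; within the scatter) and a 1.9-fold higher number from compound 2 to compound 4 (0.28 log units; within the scatter). It stands apart only from furan-3-yl, with an at least 3.4-fold higher number from compound 1 to compound 4 (0.53 log units; beyond the scatter). Compound 1 stands at a limit of the assay, so that step is only a floor: the limit of < 14 mL.min-1.g-1 in this assay, at which 1 of the 4 values shown sits.

The compounds shown leave open how an amine or a carboxylic acid carried on the aromatic ring at this carbon would read in this assay. They also leave open whether a saturated ring such as morpholine there would join compound 1 at the limit.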